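This account rests on a few compounds, and the source may have more. Where it says the series, first, only, none or still open, it means among the compounds named here.

In a functional assay on DU-145 cells (Homo sapiens) for inhibition, read by trypan blue exclusion, with a stated time of 96 h (on this read-out lower numbers stand for stronger inhibition of growth and higher numbers for weaker inhibition of growth), compound 1 (`COc1ccccc1/C=C(\C(=O)c1ccc(Cl)cc1)S(=O)(=O)Cc1ccc(Cl)c(Cl)c1`) gives 1000 nM. Compound 2 (`Cc1ccc(S/C(=C/c2cc(Cl)cc(Cl)c2Cl)C(=O)c2ccc(Cl)cc2)cc1`) gives 50000 nM, the higher of the two numbers and so the weaker inhibition of growth, and its gap to compound 1 lies beyond the usual scatter. These two compounds differ in more than one place, so their gap cannot be tied to any single change. Compound 3 (`Cc1ccc(S/C(=C/c2ccc(Cl)cc2Cl)C(=O)c2ccc(Cl)cc2)cc1`) has not yet been measured and differs from compound 2 in one group only: 2,4-dichlorophenyl in place of 2,3,5-trichlorophenyl on a double-bonded chain carbon bound to a double-bonded chain carbon. Thus 2,4-dichlorophenyl stands in place of 2,3,5-trichlorophenyl on a double-bonded chain carbon bound to a double-bonded chain carbon. For the measured compounds named here, no measured pair shows a swap of this kind, so the data offer no direct guide to its size. A modest step toward a lower number in this assay is expected, near the edge of the scatter, leaving compound 3 among the weaker inhibitors of growth. The estimated step is a 2.5-fold lower number from compound 2 to compound 3 (0.40 log units; beyond the scatter). For compound 3 the expected value is 20000 nM, with an estimated range of 5000 nM to 60000 nM.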

Compound 3, concentration for 50% growth inhibition: 10000 nM
Beside the measured number, compound 3's estimate is 2.0-fold (0.30 log units) above it; the measured number falls inside the stated range.
By their numbers in this assay, from the lowest: compound 1; then compound 3; then compound 2.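

In this assay, for the compounds shown here, placing 2,4-dichlorophenyl in place of 2,3,5-trichlorophenyl on a double-bonded chain carbon bound to a double-bonded chain carbon gives a 5.0-fold lower number from compound 2 to compound 3 (0.70 log units; beyond the scatter); this is the first single change that can be read, as the gap between compound 1 and compound 2 spans more than one place. It shows that growth inhibition in this series responds to the chlorine substitution of this phenyl group, even with the rest of the molecule held constant. Nothing measured here accounts for the size or direction of this step.

The change alters both the number of chlorines, from 3 chlorine to 2 chlorine, and their arrangement, so the compounds shown cannot separate these two contributions, nor can they tell whether the same swap would act alike on the core of compound 1. Also open, on these data alone, is how this position would respond to a phenyl group carrying an amine or a carboxylic acid in place of chlorine.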